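Fluoromethyl for hydroxymethyl on a shared diaryl core

A few compounds are considered here, and "the series" means these few. Any claim that something is new, unique, unknown or untested is made for them only; others in the source may bear on it.

Compound 1 `COc1ccc(C(c2ccc(OC)c(OC)c2)[C@@H](C)[C@H](C)CO)cc1OC`: > 100000 nM
Compound 2 `COc1cc(C(c2ccc(O)c(OC)c2)[C@@H](CO)C(C)C)ccc1O`: > 100000 nM
Compound 3 `COc1ccc(C(c2ccc(OC)c(OC)c2)[C@@H](C)[C@@H](C)CO)cc1OC`: > 100000 nM

In a functional assay on HL-60 cells (Homo sapiens) for cytotoxicity, read by WST assay, with a stated time of 48 h (on this read-out higher numbers stand for weaker inhibition and lower numbers for stronger inhibition), compound 2 gives > 100000 nM, which is a limit of the assay and not a number. The step that the two limits leave unreadable from compound 1 to compound 3 cannot be read, because the limit of > 100000 nM in this assay, at which 3 of the 3 values shown sit, and (the fact that compounds 1 and 3 differ only in the configuration as drawn). Compound 4 `COc1cc(C(c2ccc(O)c(OC)c2)[C@H](C)[C@@H](C)CF)ccc1O` arises from compound 2 through (2-(fluoromethyl)-1-methylpropyl in place of 1-(hydroxymethyl)-2-methylpropyl on a saturated chain carbon bound to two aromatic carbons). Among the measured compounds shown here, no measured step bears on this change, since every value shown is a limit. Compound 4 is therefore estimated at 100000 nM, with a range from 30000 nM to 300000 nM, most likely again only a limit. The expected step of a number no higher from compound 2 to compound 4 (the limit leaves the size open) is accordingly none beyond the scatter.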

Compound 4, half-maximal inhibitory concentration: 45000 nM
Beside the measured number, compound 4's estimate is 2.2-fold (0.35 log units) above it; the measured number falls inside the stated range.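

In this assay, 2-(fluoromethyl)-1-methylpropyl in place of 1-(hydroxymethyl)-2-methylpropyl on a saturated chain carbon bound to two aromatic carbons gives the first readable movement at this position, an at least 2.2-fold lower number from compound 2 to compound 4 (0.34 log units; beyond the scatter), and compound 4 is the only compound shown with a number. Compound 2 gives > 100000 nM, which is a limit of the assay and not a number. The step is therefore a bound and not a size, because of this: the limit of > 100000 nM in this assay, at which 3 of the 4 values shown sit.

The fluorine and the altered chain branching change together, so the compounds shown leave open which of them carries the step. On these data alone, how an aminomethyl group or a longer chain would read at this place also remains open.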